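The source may hold more compounds than are shown below. What is called first, only, known or untested is meant among the compounds shown, and "the series" means these compounds.

Measured compounds, read in an ADME assay on MDCK cells (Canis lupus familiaris) for cytotoxicity, read by microscopy, with a stated time of 48 h; on this read-out lower numbers stand for higher toxicity in this test and higher numbers for lower toxicity in this test:
compound 1, `C[C@H]1[C@H](NCc2sccc2C2CCCCC2)C[C@H]2C[C@@H]1C2(C)C`, gives 1560 nM
compound 2, `C[C@H]1[C@H](NCc2sccc2C2CCCC2)C[C@H]2C[C@@H]1C2(C)C`, gives 12500 nM
compound 3, `C[C@H]1[C@H](NCc2cc(C3CCCCC3)cs2)C[C@H]2C[C@@H]1C2(C)C`, gives 780 nM

Compound 1 and compound 2 share a core and differ only by cyclopentyl in place of cyclohexyl on an aromatic carbon. That change gave an 8.0-fold higher number from compound 1 to compound 2 (0.90 log units; beyond the scatter). Compound 3 is built from the same atoms as compound 1, joined differently; the difference between the two cores is not broken down here. The values of compound 3 and compound 1 in this assay lie within the scatter of each other, so no order between them is read.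

Compound 4, `C[C@H]1[C@H](NCc2cc(C3CCCC3)cs2)C[C@H]2C[C@@H]1C2(C)C`, is not yet measured. It differs from compound 3 by cyclopentyl in place of cyclohexyl on an aromatic carbon. This is the same kind of change as that from compound 1 to compound 2, but not the same: in compound 1 the place is next to the ring atom that bears a large group, two ring bonds from the ring sulfur, whereas in compound 3 it is two ring bonds from the ring sulfur and two ring bonds from the ring atom that bears a large group. Among the compounds with values here, with only one measured instance of the change, and at a different place, the expected step in this assay is taken somewhat smaller than the measured one: the step from compound 3 to compound 4 is estimated at a 5.8-fold higher number from compound 3 to compound 4 (0.76 log units; beyond the scatter), because compound 1 to compound 2 gave an 8.0-fold higher number from compound 1 to compound 2 (0.90 log units; beyond the scatter). Compound 4 is therefore expected to give about 4500 nM, with a likely range from 1500 nM to 15000 nM.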

Compound 4, minimum cytotoxic concentration: 1560 nM
The estimate for compound 4 lay 2.9-fold (0.46 log units) above the measured number, and the stated range covers the measured number.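

In this assay, cyclopentyl in place of cyclohexyl on the core of compound 3 gives a 2.0-fold higher number from compound 3 to compound 4 (0.30 log units; within the scatter), so no order is read within this pair. The change therefore does not carry over in size from one core to the other, and the two steps differ by more than repeated measurement would explain: the same change on two cores in this assay, an 8.0-fold higher number (0.90 log units; beyond the scatter) from compound 1 to compound 2 and a 2.0-fold higher number (0.30 log units; within the scatter) from compound 3 to compound 4, 4.0-fold (0.60 log units) apart, beyond the scatter of two such steps. Within the data shown here, with only one pair on each core, this shows that the step is not transferable across these two cores, but it does not show whether the core itself or the place on the ring sets its size, and it gives no rule for any further core.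

The compounds shown leave open how other groups at these places would read, such as phenyl, a longer alkyl chain, or a cyclohexyl carrying an amine or a carboxylic acid. They also leave open whether the two cores would diverge in the same way for any change other than this one.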